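From iodo to hydrogen on the aromatic ring

A few compounds are considered here, and "the series" means these few. Any claim that something is new, unique, unknown or untested is made for them only; others in the source may bear on it.

Compound 1 `C/C(=N\NC(=S)Nc1ccc(I)cc1)c1ccccn1` gives 59 nM
Compound 2 `CC(=NNC(=S)Nc1cccc(I)c1)c1ccccn1` gives 84 nM
Compound 3 `C/C(=N/NC(=S)Nc1ccccc1I)c1ccccn1` gives 6.1 nM

All three values come from a functional assay on U-87MG ATCC cells (Homo sapiens) for cytotoxicity, read by MTT assay, with a stated time of 48 h (a higher number here means a weaker inhibitor, a lower number a stronger inhibitor), and all three compounds carry iodo. Compound 1 (59 nM) cannot be told apart from compound 2 (84 nM), while compound 3 (6.1 nM) gives a clearly lower number than either. Compound 4 `C/C(=N\NC(=S)Nc1ccccc1)c1ccccn1` departs from compound 1 through the change hydrogen in place of iodo on an aromatic carbon which sets hydrogen in place of iodo on an aromatic carbon. Among the compounds with values here, no measured pair shows this change alone, so its size remains open. A small move toward a higher number in this assay is expected, probably within the scatter. The expected size is the estimated 1.7-fold higher number from compound 1 to compound 4 (0.23 log units; within the scatter) and no more can be claimed. Compound 4 is estimated at 100 nM (25 nM to 400 nM).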

Compound 4, half-maximal inhibitory concentration: 1.4 nM
The estimate for compound 4 lay 71-fold (1.85 log units) above the measured number; the measured number lies below the stated range.
By their numbers in this assay, from the lowest: compound 4; then compound 3; then compounds 1 and 2 (each within the scatter of the next).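

Setting hydrogen in place of iodo on this aromatic carbon, para to a large group, gives a 42-fold lower number from compound 1 to compound 4 (1.62 log units; beyond the scatter) in this assay. Within the data shown here, this is the first single change that can be read, and it shows that the iodo group is not needed for a low number at this position. Nothing at hand explains why the step is so large.

Going by these compounds, whether a fluoro, a methoxy or an amine at this position would stay as low as hydrogen remains open. So does whether removing iodo from compound 2 or compound 3 would give the same result.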